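Coumarin-bearing pyrazoline amides: cytotoxicity notes

The source may hold more compounds than are shown below. What is called first, only, known or untested is meant among the compounds shown, and "the series" means these compounds.

Measured so far:
- compound 1, `C=CCN(CC=C)CC(=O)N1N=C(C)CC1c1cc(Br)ccc1O`: 7870 nM
- compound 2, `O=C(c1ccccc1Cl)N1N=C(c2cc3ccccc3oc2=O)CC1c1ccccc1`: 5440 nM

In a functional assay on HepG2 cells (Homo sapiens) for cytotoxicity, read by MTT assay, with a stated time of 48 h (on this read-out lower numbers stand for stronger inhibition and higher numbers for weaker inhibition), compound 1 gives 7870 nM and compound 2 gives 5440 nM. Compound 2 holds the lowest of the two numbers shown, but its gap to compound 1 is within the scatter, so the two stand level on these data. The next compound, compound 3, `O=C(CN1CCCC1)N1N=C(c2cc3ccccc3oc2=O)CC1c1ccccc1`, is not yet measured in this assay. It differs from compound 2 in one place: (pyrrolidin-1-yl)methyl in place of 2-chlorophenyl on a carbonyl carbon. No step between measured compounds covers a change of this kind, so nothing shown says which way it should move. The expectation is therefore a step of a 1.3-fold higher number from compound 2 to compound 3 (0.11 log units; within the scatter), small and not clearly beyond the scatter. For compound 3 the estimated value in this assay is 7000 nM, with a range of 2500 nM to 20000 nM.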

Compound 3, half-maximal inhibitory concentration: 44300 nM
Estimate against measurement, compound 3: 6.3-fold (0.80 log units) below; the measured number lies above the stated range.
By their numbers in this assay, from the lowest: compounds 2 and 1 (each within the scatter of the next); then compound 3.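

Among the compounds shown here, at the carbonyl carbon whose other neighbour is the amide-type nitrogen in a ring, the choice of group clearly matters in this assay: (pyrrolidin-1-yl)methyl in place of 2-chlorophenyl gives an 8.1-fold higher number from compound 2 to compound 3 (0.91 log units; beyond the scatter) and thus a weaker result, the first change that can be read beyond the scatter. The change replaces a six-membered aromatic ring of carbon with a five-membered non-aromatic ring holding one hetero atom, and it also removes the chlorine, so this single step cannot separate these features. Nothing available accounts for the size of this step.

From the compounds shown here alone, it remains open whether the aromatic ring, the chlorine or the pyrrolidine nitrogen drives the difference. An unsubstituted phenyl or a (morpholin-4-yl)methyl group on the same carbonyl carbon would help to tell these apart.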